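Swapping One Fluorinated Group on a Weak Inhibitor

The source may hold more compounds than are shown below. What is called first, only, known or untested is meant among the compounds shown, and "the series" means these compounds.

Compound 1 `NS(=O)(=O)c1ccc2c(c1)C(=O)C(=O)N2Cc1cccc(C(F)(F)F)c1`: > 50000 nM (a limit)
Compound 2 `NS(=O)(=O)c1ccc2c(c1)C(=O)C(=O)N2Cc1ccc(SC(F)(F)F)cc1`: 20300 nM

Within the data shown here, in a functional assay on T47D cells (Homo sapiens) for inhibition, read by MTT assay, with a stated time of 72 h (a higher number here means a weaker inhibitor, a lower number a stronger inhibitor), compound 2 gives 20300 nM, the only true number so far. Compound 1 reaches only a limit, > 50000 nM. Compound 3 `NS(=O)(=O)c1ccc2c(c1)C(=O)C(=O)N2Cc1ccc(C(F)(F)F)cc1` shares their core and carries trifluoromethyl in place of (trifluoromethyl)sulfanyl on an aromatic carbon, para to a large group (trifluoromethyl in place of (trifluoromethyl)sulfanyl on an aromatic carbon). Among the measured compounds shown here, no measured pair shows this swap. Compound 1 also bears trifluoromethyl, so a small move toward weaker inhibition seems likely, possibly no larger than the scatter. The expected change is a 1.7-fold higher number from compound 2 to compound 3 (0.24 log units; within the scatter). For compound 3 the estimated value is 35000 nM, with an expected range of 14000 nM to 60000 nM.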

Compound 3, half-maximal inhibitory concentration: 32600 nM
Compound 3: the middle estimate sits 1.1-fold (0.03 log units) above what was measured, and the stated range covers the measured number.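

In this assay, putting trifluoromethyl in place of (trifluoromethyl)sulfanyl on an aromatic carbon, para to a large group, gives a 1.6-fold higher number from compound 2 to compound 3 (0.21 log units; within the scatter). Among these compounds, this is the first real step, and it shows that at this position the two fluorinated groups cannot be told apart in this assay. Compound 1 remains a limit, so it adds no step: the limit of > 50000 nM in this assay, at which 1 of the 3 values shown sits.

Still open, going by these compounds, is whether a quite different group at this position, such as an amine or a carboxylic acid, would shift the number beyond the scatter.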